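Farnesoyl guanidine series: a second acyl group on the guanidine

A few compounds are considered here, and "the series" means these few. Any claim that something is new, unique, unknown or untested is made for them only; others in the source may bear on it.

Measured so far:
compound 1, `CC(C)=CCC/C(C)=C/CC/C(C)=C/C(=O)NC(=N)N`: 9200 nM
compound 2, `CC(C)=CC(=O)NC(=N)N`: 92800 nM

Among the measured compounds shown here, both compounds have been tested in a functional assay on B16-F10 cells (Mus musculus) for inhibition, read by MTT assay, with a stated time of 72 h; a higher number here means a weaker inhibitor of growth, a lower number a stronger inhibitor of growth. Compound 1, `CC(C)=CCC/C(C)=C/CC/C(C)=C/C(=O)NC(=N)N`, gives 9200 nM in this assay. Compound 2, `CC(C)=CC(=O)NC(=N)N`, gives 92800 nM in this assay. For the measured compounds named here, of the two numbers, that of compound 1 is the lower; the nearest value is the one of compound 2, and that gap lies beyond the scatter.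

The next compound, compound 3, `CC(C)=CCC/C(C)=C/CC/C(C)=C/C(=O)NC(=N)NC(=O)C=C(C)C`, has not been measured. It differs from compound 1 in one place: (2-methylprop-1-en-1-yl)carbonyl in place of hydrogen on an amine nitrogen. The acyl group that enters is the same one that is already present in compound 2, now attached to the other nitrogen of the guanidine of compound 1, so that the chain of compound 1 is kept and a second carbonyl group is added.

Going by the values given here, no measured pair shows this kind of change, so its effect is not known from the data. The expectation is a step of a 1.3-fold lower number from compound 1 to compound 3 (0.12 log units; within the scatter) that stays within the scatter. Compound 3 is therefore estimated at 7000 nM in this assay, with a range from 2000 nM to 25000 nM.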

Compound 3, concentration for 50% growth inhibition: 7500 nM
Compound 3: the middle estimate sits 1.1-fold (0.03 log units) below what was measured; the range from low to high includes it.
By their numbers in this assay, from the lowest: compounds 3 and 1 (each within the scatter of the next); then compound 2.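

Replacing hydrogen with (2-methylprop-1-en-1-yl)carbonyl on an amine nitrogen of the guanidine gives a 1.2-fold lower number from compound 1 to compound 3 (0.09 log units; within the scatter) in this assay, so the group that enters leaves the value within the scatter. Among the compounds shown here, this is the first view of this nitrogen: its hydrogen can be replaced by this acyl group, with the chain of compound 1 kept, without a change that can be told from repeated measurement. Nothing in the data gives a measured reason for this outcome.

The compounds shown leave open whether other groups on this nitrogen, such as a saturated 3-methylbutanoyl group, a second farnesoyl chain or an acyl chain ending in a carboxylic acid, would also leave the value in this assay unchanged. They also leave open whether the same acyl group on this nitrogen would have a similar effect if the shorter chain of compound 2 took the place of the chain of compound 1.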